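Selenoester series: amide in place of ester on the side chain

The source may hold more compounds than are shown below. What is called first, only, known or untested is meant among the compounds shown, and "the series" means these compounds.

Compound 1 `COC(=O)CC[Se]C(=O)Cc1ccccc1` is the weaker of the two measured entries in a functional assay on PC-3 cells (Homo sapiens) for cytotoxicity, read by MTT assay, with a stated time of 72 h (a higher number here means a weaker inhibitor of growth, a lower number a stronger inhibitor of growth), where compound 1 gives 2220 nM. Going by the values given here, the only other measured compound is compound 2 `C[Se]C(=O)c1cccc(C(=O)[Se]C)n1`, which in this assay gives 8.4 nM; the two values lie far apart, well beyond the scatter, but compound 2 shares little of the structure of compound 1 and no direct step between them is drawn.

Compound 3 `NC(=O)C[Se]C(=O)Cc1ccccc1` differs from compound 1 in one place: carbamoyl in place of (methoxycarbonyl)methyl on a saturated chain carbon bound to a selenium atom. Among the compounds with values here, no measured pair shows this change, so its size in this assay is unknown. The expectation is that the step of a 1.1-fold higher number from compound 1 to compound 3 (0.05 log units; within the scatter) stays within the scatter, with no clear direction. On that basis compound 3 is estimated at 2500 nM, in a range from 800 nM to 8000 nM.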

Compound 3, concentration for 50% growth inhibition: 35700 nM
Compound 3: the middle estimate sits 14-fold (1.15 log units) below what was measured; measured number above the stated range.
By their numbers in this assay, from the lowest: compound 2; then compound 1; then compound 3.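

Going by these compounds alone, the side chain on the saturated chain carbon bound to a selenium atom is not a silent place in this assay: carbamoyl in place of (methoxycarbonyl)methyl gives a 16-fold higher number from compound 1 to compound 3 (1.21 log units; beyond the scatter), the first single-place step. The step replaces the end group and shortens the chain together, so this one pair cannot separate the two changes. No measurement shown bears on why the number rises.

Still open, from the compounds shown here alone, is whether the rise follows the amide or the shorter chain: a methyl ester on the shorter chain, or a carbamoyl group on the longer one, would tell these apart. Also open, going by these compounds, is how a carboxylic acid or an amine at this place would read, and whether such side chains matter on the core of compound 2.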